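From 4-chlorophenyl to 3-iodophenyl on the shared core

A few compounds are considered here, and "the series" means these few. Any claim that something is new, unique, unknown or untested is made for them only; others in the source may bear on it.

Measured in a functional assay on SK-MEL-28 cells (Homo sapiens) for cytotoxicity, read by CCK-8 assay, with a stated time of 24 h; on this read-out higher numbers stand for weaker inhibition and lower numbers for stronger inhibition:
Compound 1 `COc1ccccc1Oc1c(N)nc(-c2ccc(C)cc2)nc1OCCO`: 6190 nM
Compound 2 `COc1ccccc1Oc1c(N)nc(-c2ccc(Cl)cc2)nc1OCCO`: > 80000 nM

Compound 2 gives no number, only a limit: the limit of > 80000 nM in this assay, at which 1 of the 2 values shown sits. Compound 3 `COc1ccccc1Oc1c(N)nc(-c2cccc(I)c2)nc1OCCO` has 3-iodophenyl in place of 4-chlorophenyl on an aromatic carbon. Going by the values given here, one measured step bears on this, though it is a different change, chloro in place of methyl on an aromatic carbon: an at least 12-fold higher number from compound 1 to compound 2 (1.11 log units; beyond the scatter). Because compound 1 gives 6190 nM, a move toward lower numbers is expected in this assay. The estimated step is an at least 4.0-fold lower number from compound 2 to compound 3 (0.60 log units; beyond the scatter). For compound 3 the expected value is 20000 nM, with an estimated range from 5000 nM to 80000 nM.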

Compound 3, half-maximal inhibitory concentration: 11200 nM
For compound 3 the middle estimate is 1.8-fold (0.25 log units) above the measured one, and the stated range covers the measured number.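

In this assay, compound 2 gives no number, only a limit: the limit of > 80000 nM in this assay, at which 1 of the 3 values shown sits. Against that limit, the swap of 4-chlorophenyl for 3-iodophenyl gives an at least 7.1-fold lower number from compound 2 to compound 3 (0.85 log units; beyond the scatter), so at this aromatic carbon a halogen-bearing phenyl group need not reach the limit. Set against 4-methylphenyl, the same group gives a 1.8-fold higher number from compound 1 to compound 3 (0.26 log units; within the scatter), which leaves compound 1 and compound 3 within the scatter of each other. As far as these compounds go, whether the halogen or its place on the phenyl ring carries the step stays open. So does how a 3-chlorophenyl group, or a phenyl ring bearing an amine or a carboxylic acid, would read here.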